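A Small Change at the Aromatic Ring of Compound 3

The compounds below may be only part of what the source reports. "The series", "measured", "known", "first", "only" and "open" are said of these compounds alone.

Of the compounds shown here, three with a shared core have been tested in a functional assay on the whole organism (strain Sprague-Dawley) for inhibition, with Rattus norvegicus as the target, read by paw edema, with stated times of 30 min and 2 h, at a dose of 80 mg/kg by the oral route; a lower number here means less inhibition, a higher number more inhibition at the dose given (going by the name of the read-out). Compound 1 `Cc1nc2ccccc2c(=O)n1NC(=O)NC1CCCCC1` gives 41.9%, compound 2 `O=c1c2ccccc2nc(CO[N+](=O)[O-])n1NS(=O)(=O)c1ccccc1` gives 11.6%, and compound 3 `Cc1nc2ccccc2c(=O)n1NS(=O)(=O)c1ccccc1` gives 22.2%, which places compound 3 second highest of the three. Among the compounds with values here, the only measured step, a number 10.6 percentage points higher from compound 2 to compound 3 (beyond the scatter), concerns a saturated chain carbon and does not touch the aromatic ring that is altered here. Compound 4 `CC(=O)Nc1ccc(S(=O)(=O)Nn2c(C)nc3ccccc3c2=O)cc1` differs from compound 3 by acetamido in place of hydrogen on an aromatic carbon. Within the data shown here, since no measured step bears on this kind of change, no movement beyond the scatter is expected in this assay. Compound 4 is therefore estimated at 25%, within 10% to 40%, a step of a number 2.8 percentage points higher from compound 3 to compound 4 (within the scatter) expected to stay within the scatter.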

Compound 4, a percentage reported as inhibition, in the whole organism at one dose (the size of the read-out at that dose, not a potency): 37.4%
The estimate for compound 4 lay 12.4 percentage points below the measured number; the range from low to high includes it.
By their numbers in this assay, from the lowest: compound 2; then compound 3; then compounds 4 and 1 (each within the scatter of the next).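

Within the data shown here, this aromatic ring, which no earlier step touched, does matter in this assay: acetamido in place of hydrogen, para to a large group, gives a number 15.2 percentage points higher from compound 3 to compound 4 (beyond the scatter). The position can therefore carry acetamido without any loss of inhibition at this dose. No measurement available here gives a reason for the rise.

From the compounds shown here alone, it remains open whether the rise is specific to acetamido or would also appear with a plain amine or a methyl group at the same place. Going by these compounds, the same change on the core of compound 2 is also open.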